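The source may hold more compounds than are shown below. What is called first, only, known or untested is meant among the compounds shown, and "the series" means these compounds.

Measured so far in an assay on CHO cells for displacement of a labelled ligand from Free fatty acid receptor 1 (Homo sapiens), read by scintillation counting, with a stated time of 90 min, in the presence of a further agent that is not named here; on this read-out higher numbers stand for weaker inhibition and lower numbers for stronger inhibition:

Compound 1 `COc1ccc(-c2c(C)cccc2C)cc1COc1ccc(CCC(=O)O)cc1`: 520 nM
Compound 2 `COc1ccc(COc2ccc(CCC(=O)O)cc2)cc1-c1c(C)cccc1C`: 47 nM
Compound 3 `CCOCCOc1cc(C)c(-c2cccc(COc3ccc(CCC(=O)O)c(F)c3)c2)c(C)c1`: 12 nM

Among these three, compound 3 gives the lowest number in this assay. Its nearest neighbour is compound 2, whose value sits higher by an amount beyond the usual scatter, and compound 1 lies further away still, also beyond the scatter. Compound 3 is therefore the strongest inhibitor of the set as it stands.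

The next compound, compound 4 `Cc1cc(OC2CCOCC2)cc(C)c1-c1cccc(COc2ccc(CCC(=O)O)c(F)c2)c1`, is built from compound 3 by one change: oxan-4-yl in place of 2-ethoxyethyl on an oxygen on an aromatic ring. A chain gives way to a ring on the same aromatic oxygen, with the count of hydrogen-bond acceptors unchanged. Going by the values given here, no pair among the measured compounds differs by this change alone, so nothing measured speaks directly to its size or direction; the three values show only how far the other changes across the set reach.

The expected step, a 1.3-fold higher number from compound 3 to compound 4 (0.10 log units; within the scatter), is estimated to fall within the usual scatter, with no clear direction. On that basis compound 4 is expected to give about 15 nM in this assay, with a plausible range from 5 nM to 45 nM.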

Compound 4, inhibition constant: 20 nM
Compound 4: middle estimate off by 1.3-fold (0.12 log units), on the low side; the range from low to high includes it.
By their numbers in this assay, from the lowest: compounds 3 and 4 (each within the scatter of the next); then compound 2; then compound 1.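

In this assay, oxan-4-yl in place of 2-ethoxyethyl on an oxygen on an aromatic ring gives a 1.7-fold higher number from compound 3 to compound 4 (0.22 log units; within the scatter), and that step lies within the usual scatter. Going by these compounds alone, this pair is the first direct reading of the change in the set: on this oxygen, a six-membered non-aromatic ring can stand in place of an open chain with no difference in the read-out that can be told apart from repeat measurement. Nothing at hand explains why the two groups read alike.

The compounds shown leave open whether this holds for groups of another kind on the same oxygen, such as a piperidin-4-yl ring with its ring amine, a chain ending in a carboxylic acid, or a longer ether chain. Within the data shown here, with a single pair behind it, they also leave open whether the exchange of 2-ethoxyethyl for oxan-4-yl would read the same way on a core other than the one shared by compound 3 and compound 4.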